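This account rests on a few compounds, and the source may have more. Where it says the series, first, only, none or still open, it means among the compounds named here.

Of the compounds shown here, three have been measured in an ADME assay on RAW264.7 cells (Mus musculus) for cytotoxicity, read by MTT assay, with a stated time of 48 h; on this read-out higher numbers stand for weaker inhibition and lower numbers for stronger inhibition. Compound 1 `Cc1cc(NC(=O)c2ccc(Cl)cc2)ccc1NS(=O)(=O)C(F)(F)F` gives 35400 nM in this assay. Compound 2 `Cc1cc(NC(=O)c2ccc(Cl)c([N+](=O)[O-])c2)ccc1NS(=O)(=O)C(F)(F)F` differs from compound 1 by nitro in place of hydrogen on an aromatic carbon, and in this assay compound 2 gives 89800 nM, which is a 2.5-fold higher number from compound 1 to compound 2 (0.40 log units; beyond the scatter). Compound 3 `O=C(Nc1ccc(NS(=O)(=O)C(F)(F)F)c(F)c1)c1ccc(Cl)cc1` differs from compound 1 by fluoro in place of methyl on an aromatic carbon; in this assay compound 3 gives 3270 nM, which is an 11-fold lower number from compound 1 to compound 3 (1.03 log units; beyond the scatter), the lowest number of the three. Compound 4 `O=C(Nc1ccc(NS(=O)(=O)C(F)(F)F)c(F)c1)c1ccc(Cl)c([N+](=O)[O-])c1` has not been measured yet. It differs from compound 3 by nitro in place of hydrogen on an aromatic carbon, the same change that separates compound 2 from compound 1, on a core that differs from the core of compound 1 as described above. Because compound 1 to compound 2 gave a 2.5-fold higher number from compound 1 to compound 2 (0.40 log units; beyond the scatter), a step of similar size is expected from compound 3 to compound 4, namely a 2.4-fold higher number from compound 3 to compound 4 (0.39 log units; beyond the scatter). Compound 4 is therefore estimated to give about 8000 nM in this assay.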

Compound 4, half-maximal inhibitory concentration: 188000 nM
Beside the measured number, compound 4's estimate is 24-fold (1.37 log units) below it; the whole stated range lies below it.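

Nitro in place of hydrogen gave a 57-fold higher number from compound 3 to compound 4 (1.76 log units; beyond the scatter) in this assay, and this step does not match the one on the core of compound 1: the same change on two cores in this assay, a 2.5-fold higher number (0.40 log units; beyond the scatter) from compound 1 to compound 2 and a 57-fold higher number (1.76 log units; beyond the scatter) from compound 3 to compound 4, 23-fold (1.36 log units) apart, beyond the scatter of two such steps

Read the other way, fluoro in place of methyl gave a 2.1-fold higher number from compound 2 to compound 4 (0.32 log units; beyond the scatter), which does not match its earlier step in size or direction: the same change on two cores in this assay, an 11-fold lower number (1.03 log units; beyond the scatter) from compound 1 to compound 3 and a 2.1-fold higher number (0.32 log units; beyond the scatter) from compound 2 to compound 4, 23-fold (1.36 log units) apart, beyond the scatter of two such steps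

So, across these four compounds, a step measured on one core cannot simply be carried to the other, but the data do not show why, or how either change would behave on any further core.

Going by these compounds, it remains open whether an amine or a nitrile on the same aromatic carbon, ortho to a chloro group, would also differ so strongly between the two cores. On these data alone, it is equally open how a methoxy group in place of the fluoro would behave.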